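The source may report more compounds than this note shows. Statements on the series, on what has been measured and on what is new or still open speak of the compounds shown alone.

Two compounds of the shared core have numbers in a functional assay on HL-60 cells (Homo sapiens) for antiproliferative activity, with a stated time of 24 h; on this read-out higher numbers stand for weaker inhibition and lower numbers for stronger inhibition. Compound 1 `NC(=O)c1c(NC(=O)c2ccccc2Cl)sc2c1CCN(C(=S)Nc1ccccc1Br)C2` gives 9090 nM. Compound 2 `NC(=O)c1c(NC(=O)c2ccccc2Cl)sc2c1CCN(C(=S)Nc1c(Cl)cccc1Cl)C2` gives 3950 nM, the lowest of the two numbers shown, and the single measured step, a 2.3-fold lower number from compound 1 to compound 2 (0.36 log units; beyond the scatter), separates it from compound 1 beyond the scatter. Compound 3 `NC(=O)c1c(NC(=O)c2ccccc2Cl)sc2c1CCN(C(=O)Nc1c(Cl)cccc1Cl)C2` is not yet measured in this assay. It differs from compound 2 by a group of 11 heavy atoms (7 carbon, 1 nitrogen, 1 oxygen, 2 chlorine; one six-membered aromatic ring of carbon only) in place of a group of 11 heavy atoms (7 carbon, 1 nitrogen, 1 sulfur, 2 chlorine; one six-membered aromatic ring of carbon only), on an amine nitrogen in a ring. Among the compounds with values here, the one measured step concerns the aromatic ring on the amide-type nitrogen and not the atom exchanged here, so no measured step bears directly on the change from compound 2 to compound 3; the series gives no guidance on an exchange of this kind, and the size and direction of the step are open. With nothing to anchor it, the expected number for compound 3 is placed close to that of compound 2, with a wide range on both sides, as a 1.5-fold higher number from compound 2 to compound 3 (0.18 log units; within the scatter). Compound 3 is therefore estimated at 6000 nM, between 2000 nM and 20000 nM.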

Compound 3, half-maximal inhibitory concentration: 17700 nM
Compound 3: the middle estimate sits 3.0-fold (0.47 log units) below what was measured; the range from low to high includes it.
By their numbers in this assay, from the lowest: compound 2; then compounds 1 and 3 (each within the scatter of the next).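

In this assay, within the data shown here, the first change at the amine nitrogen in a ring, rather than on the aromatic ring alone, gives a 4.5-fold higher number from compound 2 to compound 3 (0.65 log units; beyond the scatter): exchanging sulfur for oxygen in a group of equal heavy-atom count, with the 2,6-dichlorophenyl ring kept, is enough to move the number beyond the scatter. The step of a 1.9-fold higher number from compound 1 to compound 3 (0.29 log units; within the scatter) shows that the (2,6-dichlorophenyl)carbamoyl group is not separated from the sulfur-containing group of compound 1 in this assay, so the 2,6-dichlorophenyl ring does not give a number apart from compound 1 once oxygen is present. No available evidence accounts for the effect of the exchange, and the data give no reason for it.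

The compounds shown leave open whether oxygen in place of sulfur moves the number in the same direction with the 2-bromophenyl group, or with an unsubstituted phenyl ring. Also open, from the compounds shown here alone, is how the number responds when the group on this nitrogen has neither sulfur nor oxygen in that place, as with a benzyl group, or when the aromatic ring gives way to a short alkyl chain.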